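Trading a Phenylsulfonyl Cap for a 3-Chlorophenyl Group

This account rests on a few compounds, and the source may have more. Where it says the series, first, only, none or still open, it means among the compounds named here.

Compound 1 `NCCNc1cc(N2CCN(S(=O)(=O)c3ccccc3)CC2)nc2ccccc12` was tested in an ADME assay on HEp-2 cells (Homo sapiens) for cytotoxicity, read by CCK-8 assay, with a stated time of 6 days (on this read-out higher numbers stand for lower toxicity in this test and lower numbers for higher toxicity in this test), where compound 1 gives 20500 nM. Compound 2 `NCC(O)CNc1cc(N2CCC(c3ccccc3)CC2)nc2ccccc12`, which shares the core but carries different groups at two places, gives 20800 nM in this assay. These two numbers lie within the scatter of each other, so on the evidence so far compound 1 stands level with its only companion rather than apart from it. Compound 3 `NCCNc1cc(N2CCN(c3cccc(Cl)c3)CC2)nc2ccccc12` is not yet measured; it differs from compound 1 in one place: 3-chlorophenyl in place of phenylsulfonyl on an amine nitrogen in a ring. For the measured compounds named here, no pair of measured compounds shows what this change does to the read-out, so there is no measured step to lean on. The expected step from compound 1 to compound 3 in this assay is small, a 1.1-fold lower number from compound 1 to compound 3 (0.06 log units; within the scatter), and not beyond the scatter. Compound 3 is expected to give 18000 nM, with a likely range from 7000 nM to 45000 nM.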

Compound 3, half-maximal cytotoxic concentration: 6400 nM
Beside the measured number, compound 3's estimate is 2.8-fold (0.45 log units) above it; measured number outside the range, below it.
By their numbers in this assay, from the lowest: compound 3; then compounds 1 and 2 (each within the scatter of the next).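

In this assay, 3-chlorophenyl in place of phenylsulfonyl on the amine nitrogen in the ring gives a 3.2-fold lower number from compound 1 to compound 3 (0.51 log units; beyond the scatter), and a lower number here stands for higher toxicity in this test. This is the first step among these compounds that isolates a single change, and it shows that the group at this position can move the read-out beyond the scatter. The data offer no measurement that explains the step.

A single step cannot show whether the chlorine, the loss of the sulfonyl link, or both account for it. A plain phenyl or a 4-chlorophenyl on the same nitrogen would help separate these possibilities, while a methylsulfonyl group would test the sulfonyl link without its phenyl ring.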